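Nitrone series: trifluoromethyl entering the aryl ring of compound 3

This account rests on a few compounds, and the source may have more. Where it says the series, first, only, none or still open, it means among the compounds named here.

Of the compounds shown here, three have been measured in a functional assay on MDA-MB-231 cells (Homo sapiens) for inhibition, read by MTT assay, with a stated time of 24 h; on this read-out lower numbers stand for stronger inhibition and higher numbers for weaker inhibition. Compound 1 `[O-]/[N+](=C\c1cn(-c2ccc(Cl)cc2)nn1)c1ccccc1` gives 8900 nM in this assay. Compound 2 `[O-]/[N+](=C\c1cn(CCC(F)(F)C(F)(F)C(F)(F)C(F)(F)C(F)(F)C(F)(F)C(F)(F)C(F)(F)F)nn1)c1ccccc1` reaches only the limit of this assay, > 100000 nM. Compound 3 `[O-]/[N+](=C\c1cn(-c2ccccc2)nn1)Cc1ccccc1` likewise gives only the limit, > 100000 nM, in this assay. So compound 3 stands at the limit of > 100000 nM in this assay, at which 2 of the 3 values shown sit, and no numbered value is known for it. Within the data shown here, no pair among the measured compounds differs in one place, so no step can be computed; compound 1 and compound 3 differ in more than one place, and their values show only that compound 1 has a number while compound 3 does not.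

Compound 4 `[O-]/[N+](=C\c1cn(-c2ccc(C(F)(F)F)cc2)nn1)Cc1ccccc1` is not yet measured. It differs from compound 3 by trifluoromethyl in place of hydrogen on an aromatic carbon. With compound 3 sitting at the limit, the expected step from compound 3 to compound 4 in this assay is an at least 1.6-fold lower number from compound 3 to compound 4 (0.22 log units; that floor lies within the scatter), at most a modest move toward stronger inhibition, quite possibly none beyond the scatter. Compound 4 is therefore estimated at 60000 nM in this assay, within a range of 10000 nM to 300000 nM, with a substantial chance that only a limit is reported.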

Compound 4, half-maximal inhibitory concentration: > 100000 nM
Compound 4 was reported as a limit; the forecaster's own chance of this, stated with the estimate: 55%; middle value at least 1.6-fold (0.22 log units) away from the limit.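

Compound 3 and compound 4 are both reported only as limits, so no step between them can be read: the limit of > 100000 nM in this assay, at which 3 of the 4 values shown sit.

The compounds shown leave open whether trifluoromethyl in place of hydrogen on an aromatic carbon changes inhibition at all in this series.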